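Solubility notes ahead of the reading for compound 4

The compounds below may be only part of what the source reports. "The series", "measured", "known", "first", "only" and "open" are said of these compounds alone.

The series shares one core; compound 1 `CC(C)CCn1nc(CC(C)(C)C)c(O)c(C2=NS(=O)(=O)c3cc(NS(C)(=O)=O)ccc3N2)c1=O`, compound 2 `CC(C)CCn1nc(C(C)(C)C)c(O)c(C2=NS(=O)(=O)c3cc(NS(C)(=O)=O)ccc3N2)c1=O` and compound 3 `CC(C)=Cc1nn(CCC(C)(C)C)c(=O)c(C2=NS(=O)(=O)c3cc(NS(C)(=O)=O)ccc3N2)c1O` have been run in a physicochemical assay for solubility, at pH 7.4; a lower number here means a less soluble compound, a higher number a more soluble compound. In this assay compound 1 reaches the limit > 100000 nM. Compound 2 likewise sits at the limit > 100000 nM. Compound 3 also stands only at the limit > 100000 nM. Among the compounds with values here, the sole single-point step, a step that the two limits leave unreadable from compound 1 to compound 2, is therefore unreadable, and the limit of > 100000 nM in this assay, at which 3 of the 3 values shown sit, is all the evidence there is. Compound 4 `CC(C)(C)CCn1nc(C2CC2)c(O)c(C2=NS(=O)(=O)c3cc(NS(C)(=O)=O)ccc3N2)c1=O` differs from compound 3 by cyclopropyl in place of 2-methylprop-1-en-1-yl on an aromatic carbon. Within the data shown here, no measured step bears on this change. Among the measured compounds shown here, with every value so far at the limit, compound 4 is expected to stay there as well, estimated at 100000 nM (range 40000 nM to 250000 nM). The implied step a number no higher from compound 3 to compound 4 (the limit leaves the size open) is expected to lie within the scatter.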

Compound 4, solubility: > 50000 nM
Compound 4: no number, only a limit; the forecaster's own chance of this, stated with the estimate: 75%; the middle value lies beyond the limit too.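

In this assay compound 4 gives > 50000 nM, which is a limit and not a number. Compound 3 also holds only a limit, so the step between these two compounds cannot be read. The compounds shown leave open whether any change among them alters solubility at all.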